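Replacing the Ester-Bearing Chain on the Amine of Compound 2

The compounds below may be only part of what the source reports. "The series", "measured", "known", "first", "only" and "open" are said of these compounds alone.

For the measured compounds named here, compound 2 `CCC(Nc1nc(C)nc2c1nnn2-c1ccc(C(C)C)cc1Br)C(=O)OC` holds the higher of the two numbers so far obtained in an in vitro assay on 293-EBNA cells for binding affinity to corticotropin-releasing factor receptor 1 (Homo sapiens) (on this read-out lower numbers stand for stronger inhibition and higher numbers for weaker inhibition), giving 19.4 nM. Going by the values given here, its only neighbour is compound 1 `CCC(COC)N(C)c1nc(C)nc2c1nnn2-c1ccc(C(C)C)cc1Br`, which in this assay gives 11.2 nM. The step of a 1.7-fold higher number from compound 1 to compound 2 (0.24 log units; within the scatter) stays within the scatter, so the two measured compounds cannot be told apart on this read-out.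

Compound 3 `COCCCNc1nc(C)nc2c1nnn2-c1ccc(C(C)C)cc1Br` differs from compound 2 in one place: 3-methoxypropyl in place of 1-(methoxycarbonyl)propyl on a nitrogen on an aromatic ring. Among the compounds with values here, no measured step touches this exact exchange; the one step that exists, the one between compound 1 and compound 2, also changed the group on this ring nitrogen and produced no shift beyond the scatter. Both measured compounds carry a short chain with an oxygen on this nitrogen, and compound 3 keeps such a chain while losing the carbonyl. On that basis the expected step of a 1.0-fold higher number from compound 2 to compound 3 (0.01 log units; within the scatter) is small, with no direction beyond the scatter. Compound 3 is therefore estimated at 20 nM in this assay, between 7 nM and 60 nM.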

Compound 3, inhibition constant: 291 nM
For compound 3 the middle estimate is 15-fold (1.16 log units) below the measured one; the whole stated range lies below it.
By their numbers in this assay, from the lowest: compounds 1 and 2 (each within the scatter of the next); then compound 3.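

In this assay, the group on this nitrogen proves able to move the number by far more than the scatter: a 15-fold higher number from compound 2 to compound 3 (1.18 log units; beyond the scatter), although the earlier step between two different groups here stayed within it. Compound 3 also stands apart from the other compound, a 26-fold higher number from compound 1 to compound 3 (1.41 log units; beyond the scatter), so a chain carrying an oxygen is not enough on its own to keep the number of compounds 1 and 2. Among the three compounds, the two whose groups branch at the carbon on the nitrogen give the lower numbers and the unbranched 3-methoxypropyl of compound 3 gives the higher one, with no compound against this pattern, but no measurement shown here accounts for the loss.

The exchange from compound 2 to compound 3 removes the carbonyl and the branch together, so the compounds shown cannot say which of the two changes carries the step. Also open, on these data alone, is how this position would respond to an unbranched chain ending in a methyl ester, or to a branched chain of the same kind ending in a hydroxyl group or an amine.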